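Moving two isopropyl groups on a fatty ester

The source may hold more compounds than are shown below. What is called first, only, known or untested is meant among the compounds shown, and "the series" means these compounds.

In a functional assay on MDA-MB-231 cells (Homo sapiens) for inhibition, read by WST assay, with a stated time of 48 h (a higher number here means a weaker inhibitor of growth, a lower number a stronger inhibitor of growth), the measured compounds are these
compound 1 `CC/C=C\C/C=C\C/C=C\C/C=C\C/C=C\C/C=C\CCC(=O)Oc1ccc(C(C)C)cc1C(C)C` gives 12600 nM
compound 2 `CC/C=C\C/C=C\C/C=C\C/C=C\C/C=C\C/C=C\CCC(=O)Oc1ccccc1` gives > 25000 nM
compound 3 `CC/C=C\C/C=C\C/C=C\C/C=C\C/C=C\C/C=C\CCC(=O)Nc1c(C(C)C)cccc1C(C)C` gives 5500 nM

Of the two readings that are true numbers, compound 1 has the higher, which makes it the weaker growth inhibitor, and compound 3 lies lower by a gap beyond the usual scatter. The reading for compound 2 is a limit and not a number, as the limit of > 25000 nM in this assay, at which 1 of the 3 values shown sits, shows.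

Compound 4 `CC/C=C\C/C=C\C/C=C\C/C=C\C/C=C\C/C=C\CCC(=O)Oc1c(C(C)C)cccc1C(C)C` has not been measured. It carries 2,6-diisopropylphenyl in place of 2,4-diisopropylphenyl on an oxygen next to a carbonyl group and so differs from compound 1 only in how the same atoms are joined.

Going by the values given here, the one measured step at this place an at least 1.9-fold higher number from compound 1 to compound 2 (0.29 log units; that floor lies within the scatter) brings in phenyl and ends at a limit, so it offers only a floor within the scatter and says nothing about moving a group. Compound 3 at 5500 nM has the same 2,6-diisopropylphenyl group, but on an amide, so it is only a weak hint toward a lower number.

The expected change is small, with a 1.3-fold lower number from compound 1 to compound 4 (0.10 log units; within the scatter) as the estimate and nothing beyond the scatter expected in this assay here. Compound 4 is estimated at 10000 nM with an expected range from 5000 nM to 22000 nM in this measurement.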

Compound 4, concentration for total growth inhibition: 4200 nM
Compound 4: the middle estimate sits 2.4-fold (0.38 log units) above what was measured; the whole stated range lies above it.
By their numbers in this assay, from the lowest: compounds 4 and 3 (each within the scatter of the next); then compound 1. At a limit, above all of these: compound 2.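

Swapping 2,4-diisopropylphenyl for 2,6-diisopropylphenyl on the oxygen changes no atom, only how the atoms are joined, yet in this assay it gives a 3.0-fold lower number from compound 1 to compound 4 (0.48 log units; beyond the scatter), so the arrangement of the two isopropyl groups on this ester has a readable effect on growth inhibition, which the earlier compounds could not show. Against the unsubstituted ring, the same group gives an at least 5.9-fold lower number from compound 2 to compound 4 (0.77 log units; beyond the scatter), a step that, unlike the one from compound 1 to compound 2, clears the scatter. The reading for compound 2 is a limit and not a number, so this step gives only a minimum size: the limit of > 25000 nM in this assay, at which 1 of the 4 values shown sits.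

Compound 3 and compound 4 lie within the scatter of each other, so the compounds shown do not separate the amide from the ester when 2,6-diisopropylphenyl is present. Still open, as far as these compounds go, is how far this effect extends, for instance whether a ring with a single isopropyl group, with tert-butyl groups in place of the isopropyl groups, or with a carboxylic acid would read the same way, and whether a shorter chain would keep the difference between compound 1 and compound 4.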